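Paw edema: from compound 3 to compound 4

The source may report more compounds than this note shows. Statements on the series, on what has been measured and on what is new or still open speak of the compounds shown alone.

Measured so far:
compound 1 `CNC(=O)c1nc(-c2cc(OC)c(OC)c(OC)c2)n(-c2ccc(OC)cc2)n1`: 95%
compound 2 `CCNC(=O)c1nc(-c2cc(OC)c(OC)c(OC)c2)n(-c2ccc(OC)cc2)n1`: 88%
compound 3 `COc1ccc(-n2nc(C(=O)Nc3ccc(C)cc3)nc2-c2cc(OC)c(OC)c(OC)c2)cc1`: 77%

In a functional assay on the whole organism for inhibition, with Rattus norvegicus as the target, read by paw edema, with stated times of 30 min and 3 h, at a dose of 0.28 mmol/kg by the oral route (on this read-out higher numbers stand for more inhibition at the one dose given (going by the name of the read-out) and lower numbers for less inhibition), compound 3 gives the lowest of the three numbers; compound 2 is nearest to it and compound 1 furthest. The steps that reach compound 3 are a number 18 percentage points lower from compound 1 to compound 3 (beyond the scatter) and a number 11 percentage points lower from compound 2 to compound 3 (beyond the scatter), both beyond the scatter and both of modest size, and both exchanging a small saturated chain for an aromatic ring on the amide-type nitrogen. Compound 4 `COc1ccc(-n2nc(C(=O)Nc3cccc(F)c3)nc2-c2cc(OC)c(OC)c(OC)c2)cc1` differs from compound 3 by 3-fluorophenyl in place of 4-methylphenyl on an amide-type nitrogen. For the measured compounds named here, no measured step exchanges one aromatic ring for another at this position, so the two steps that end in compound 3 bear on it only in showing that the aromatic rings so far sit modestly below the chains. For compound 4 the expected step is a number 2 percentage points lower from compound 3 to compound 4 (within the scatter), which is within the scatter. Compound 4 is therefore estimated at 75%, in a range from 60% to 88%.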

Compound 4, a percentage reported as inhibition, in the whole organism at one dose (the size of the read-out at that dose, not a potency): 92%
For compound 4 the middle estimate is 17 percentage points below the measured one, outside the stated range (above it).
By their numbers in this assay, from the lowest: compound 3; then compounds 2, 4 and 1 (each within the scatter of the next).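

In this assay, the aromatic ring on the amide-type nitrogen proves to matter in its own right: the exchange of 4-methylphenyl for 3-fluorophenyl gives a number 15 percentage points higher from compound 3 to compound 4 (beyond the scatter), the first measured step from one aromatic ring to another at this position. The modest shortfall of compound 3 against the small chains therefore does not extend to every aromatic ring, since the steps read a number 4 percentage points higher from compound 2 to compound 4 (within the scatter) and a number 3 percentage points lower from compound 1 to compound 4 (within the scatter), so 3-fluorophenyl is not separated from ethyl or methyl here. Nothing given here accounts for the difference between the two rings.

The change replaces the methyl with a fluorine and also moves the substituent, and the compounds shown cannot separate these two differences. As far as these compounds go, how a plain phenyl ring, a longer chain or an amine-bearing chain would read at this nitrogen remains open.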